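Capping a phenolic hydroxy in compound 1

The source may hold more compounds than are shown below. What is called first, only, known or untested is meant among the compounds shown, and "the series" means these compounds.

Going by the values given here, in a functional assay on Hs-578T cells (Homo sapiens) for cytotoxicity, read by sulforhodamine B assay, with a stated time of 48 h (on this read-out lower numbers stand for stronger inhibition of growth and higher numbers for weaker inhibition of growth), compound 1 (`COc1cc(C(=O)c2ccc(OC)c(O)c2OC)cc(OC)c1O`) gives 358 nM, the lower of the two numbers available so far. Compound 2 (`COc1cc(C(=O)c2ccc3c(c2)oc(=O)n3S(C)(=O)=O)cc(OC)c1OC`) gives 3160 nM, and this gap lies beyond the usual scatter of repeated measurements. The two compounds differ in more than one place, so this pair does not isolate any single structural change.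

Compound 3 (`COc1ccc(C(=O)c2cc(OC)c(OC)c(OC)c2)c(OC)c1O`) has not yet been measured in this assay. Its structure departs from compound 1 at one place, with methyl in place of hydrogen on an oxygen on an aromatic ring, a change from hydroxy to methoxy (methyl in place of hydrogen on an oxygen on an aromatic ring). Among the compounds with values here, no measured pair shows this change, so neither its size nor its direction has direct support from the data, and the expectation is a judgement with wide uncertainty.

A moderate shift towards stronger inhibition of growth, beyond the scatter, is expected, with the estimated step of a 3.0-fold lower number from compound 1 to compound 3 (0.47 log units; beyond the scatter). For compound 3 the estimated value is 120 nM, with an expected range of 25 nM to 600 nM.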

Compound 3, concentration for 50% growth inhibition: < 10 nM
Compound 3 was reported as a limit; the forecaster's own chance of this, stated with the estimate: 3%; middle value at least 12-fold (1.07 log units) away from the limit.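

In this assay compound 3 gives < 10 nM, which is a limit of the assay and not a number. Going by these compounds alone, replacing hydroxy with methoxy, with methyl in place of hydrogen on an oxygen on an aromatic ring, gives the first single-place comparison, and it reads as an at least 35-fold lower number from compound 1 to compound 3 (1.55 log units; beyond the scatter); the hydrogen on this oxygen is therefore not required for strong inhibition of growth in this pair, and its replacement by methyl brings a large gain. The step has a known minimum but no known full size: the limit of < 10 nM in this assay, at which 1 of the 3 values shown sits.

Still open, on these data alone, is whether a longer chain on this oxygen, such as ethyl or propyl, or an amine or a carboxylic acid in place of the hydroxy, would retain this gain, since one methyl group on one core cannot define the tolerated range at this place. Also open, as far as these compounds go, is what the hydroxy that remains in compound 3 contributes, and any comparison with a stronger compound would need a value that is not a limit.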